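This account rests on a few compounds, and the source may have more. Where it says the series, first, only, none or still open, it means among the compounds named here.

Working notes on the series, read in a functional assay on MOLT-4 cells (Homo sapiens) for antiproliferative activity; a lower number here means a stronger inhibitor, a higher number a weaker inhibitor. Among the compounds with values here, compound 1 `COc1cc(C(=O)c2sc(-c3ccccc3)cc2N)cc(OC)c1OC` gives 5.3 nM, and compound 2 `COc1cc(C(=O)c2sc(-c3ccccc3Cl)cc2N)cc(OC)c1OC` gives 17 nM, the higher of the two numbers so far. Compound 3 `COc1cc(C(=O)c2sc(-c3ccc(Cl)c(Cl)c3)cc2N)cc(OC)c1OC` is not yet measured. It carries 3,4-dichlorophenyl in place of 2-chlorophenyl on an aromatic carbon, next to the ring sulfur: 3,4-dichlorophenyl in place of 2-chlorophenyl on an aromatic carbon. Within the data shown here, only one measured step bears on this change, a 3.2-fold higher number from compound 1 to compound 2 (0.51 log units; beyond the scatter), a modest step beyond the scatter for chloro in place of hydrogen on an aromatic carbon. Among the measured compounds shown here, it is an imperfect guide, as the series holds no measured compound with a 3,4-dichlorophenyl group. For the measured compounds named here, a further modest rise in the number is expected, no larger than that step. The expected step is a 1.8-fold higher number from compound 2 to compound 3 (0.25 log units; within the scatter). For compound 3 the estimated value is 30 nM, with an expected range of 10 nM to 90 nM.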

Compound 3, half-maximal inhibitory concentration: 270 nM
Compound 3: middle estimate off by 9.0-fold (0.95 log units), on the low side, outside the stated range (above it).
By their numbers in this assay, from the lowest: compound 1; then compound 2; then compound 3.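

In this assay, the step of a 16-fold higher number from compound 2 to compound 3 (1.20 log units; beyond the scatter) is large, whereas a 3.2-fold higher number from compound 1 to compound 2 (0.51 log units; beyond the scatter) is only modest, so the number at this position depends strongly on which chlorinated phenyl group is present, not merely on chloro being there. Read against the unsubstituted ring, the change gives a 51-fold higher number from compound 1 to compound 3 (1.71 log units; beyond the scatter), which leaves phenyl with the lowest number of the three groups and 3,4-dichlorophenyl with the highest. No measurement shown accounts for the size of this rise.

The compounds shown leave open whether the rise would follow 3-chlorophenyl or 4-chlorophenyl alone, as both chloro groups enter together in compound 3. They also leave open how a group other than chloro on the phenyl ring, such as fluoro, methoxy or an amine, would read here.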